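The source may report more compounds than this note shows. Statements on the series, on what has been measured and on what is new or still open speak of the compounds shown alone.

In an assay on HEK293 cells for displacement of a labelled ligand from NPC1-like intracellular cholesterol transporter 1 (Homo sapiens) (on this read-out higher numbers stand for weaker inhibition and lower numbers for stronger inhibition), compound 1 `CC(C)(C)OC(=O)NCCCCCNC(=O)CN1CN(c2ccccc2)C2(CCN(C(=O)c3ccc(C(C)(C)C)cc3)CC2)C1=O` gives 13700 nM, the higher of the two numbers recorded here. The other measured compound, compound 2 `O=C(CN1CN(c2ccccc2)C2(CCN(C(=O)c3ccc(C4CCCCC4)cc3)CC2)C1=O)N1CCCCC1`, gives 1100 nM in this assay, a lower value that lies beyond the scatter of the method. Going by the values given here, no single-point step between the two measured compounds is recorded, so the gap between them is stated only as what the two values show.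

Compound 3 `CC(C)(C)c1ccc(C(=O)N2CCC3(CC2)C(=O)N(CC(=O)NCCCCCO)CN3c2ccccc2)cc1` has not yet been measured in this assay. It differs from compound 1 in one place: hydroxy in place of (tert-butoxycarbonyl)amino on a saturated chain carbon, five bonds along the chain from an amide-type nitrogen. The shared core and the rest of the chain are unchanged.

Among the compounds with values here, with no measured pair of this kind to lean on, the size of the step is uncertain. The change is expected to move this assay by little, with a step of a 1.5-fold lower number from compound 1 to compound 3 (0.18 log units; within the scatter) that most likely stays within, or only slightly beyond, the scatter of repeated measurements. Compound 3 is therefore estimated at 9000 nM, with a range from 3000 nM to 30000 nM.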

Compound 3, half-maximal inhibitory concentration: 9400 nM
The estimate for compound 3 lay 1.0-fold (0.02 log units) below the measured number; the measured number falls inside the stated range.
By their numbers in this assay, from the lowest: compound 2; then compounds 3 and 1 (each within the scatter of the next).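

Replacing (tert-butoxycarbonyl)amino with hydroxy on a saturated chain carbon, five bonds along the chain from an amide-type nitrogen, gives a 1.5-fold lower number from compound 1 to compound 3 (0.16 log units; within the scatter) in this assay. Compound 1 and compound 2 differ in more than one place, so they could say nothing about this position alone, whereas this pair shows that the whole (tert-butoxycarbonyl)amino group, with its carbonyl and tert-butyl parts, can give way to a single oxygen-bearing group without a change beyond the scatter. Nothing measured here accounts for this result.

From the compounds shown here alone, it remains open whether the same holds for other groups at the end of this chain, such as a primary amine or a carboxylic acid, or for a shorter or longer chain carrying the hydroxy. The value of 1100 nM for compound 2 also cannot be traced to any single part of its structure, as compound 2 differs from both compound 1 and compound 3 in more than one place, and no compound shown links it to them one change at a time.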